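Oral exposure across amine-bearing side chains on the core

The compounds below may be only part of what the source reports. "The series", "measured", "known", "first", "only" and "open" are said of these compounds alone.

Measured compounds:
compound 1 `NCCOc1ccc([C@H]2CC[C@]3(CC2)OOC2(O3)C3CC4CC(C3)CC2C4)cc1` — 287 nM
compound 2 `c1cc([C@H]2CC[C@]3(CC2)OOC2(O3)C3CC4CC(C3)CC2C4)ccc1OCCC1CCNCC1` — 1190 nM
compound 3 `c1cc([C@H]2CC[C@]3(CC2)OOC2(O3)C3CC4CC(C3)CC2C4)ccc1OCC1CCNCC1` — 465 nM

In an ADME assay on the whole organism (strain FVB) for pharmacokinetics, with Mus musculus as the target, read by LC-MS, at a dose of 30 mg/kg by the oral route (on this read-out higher numbers stand for higher exposure at the dose given and lower numbers for lower exposure), compound 1 gives 287 nM, the lowest of the three numbers; compound 3 lies nearest to it and compound 2 furthest. The two steps out of compound 1 both run upward: a 4.1-fold higher number from compound 1 to compound 2 (0.62 log units; beyond the scatter), whereas a 1.6-fold higher number from compound 1 to compound 3 (0.21 log units; within the scatter). Between the two larger side chains, a 2.6-fold lower number from compound 2 to compound 3 (0.41 log units; beyond the scatter).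

Compound 4 `N[C@H]1CC[C@@H](Oc2ccc([C@H]3CC[C@]4(CC3)OOC3(O4)C4CC5CC(C4)CC3C5)cc2)CC1` has not yet been measured in this assay. Relative to compound 1 the change is 4-aminocyclohexyl in place of 2-aminoethyl on an oxygen on an aromatic ring. Both measured steps from compound 1 bear on it, since each also brought in a six-membered non-aromatic ring in place of a short chain while keeping one donor and one acceptor, and each raised the number, one beyond the scatter and one within it. A modest rise is therefore expected, a 1.8-fold higher number from compound 1 to compound 4 (0.26 log units; within the scatter), rather than a fall. For compound 4 the estimate is 520 nM, with a range from 200 nM to 1350 nM.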

Compound 4, maximal plasma concentration: 1170 nM
For compound 4 the middle estimate is 2.3-fold (0.35 log units) below the measured one; measured number inside the range.
By their numbers in this assay, from the lowest: compounds 1 and 3 (each within the scatter of the next); then compounds 4 and 2 (each within the scatter of the next).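

In this assay a ring of carbon only carrying the amine, set directly on the oxygen on the aromatic ring, lifts the number clearly over 2-aminoethyl (a 4.1-fold higher number from compound 1 to compound 4 (0.61 log units; beyond the scatter)). The 4-aminocyclohexyl group also stands clear of the (piperidin-4-yl)methyl group (a 2.5-fold higher number from compound 3 to compound 4 (0.40 log units; beyond the scatter)), so compound 3 goes against any reading that a six-membered non-aromatic ring alone carries the rise. It matches the 2-(piperidin-4-yl)ethyl group (a 1.0-fold lower number from compound 2 to compound 4 (0.01 log units; within the scatter)), so the level of compound 2 no longer belongs to one side chain only.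

Still open, going by these compounds, is whether a 3-aminocyclohexyl or a 4-(dimethylamino)cyclohexyl group would hold this level, and how the other stereoisomer of the 4-aminocyclohexyl group would compare. Nothing at hand explains the differences among these side chains.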